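The compounds below may be only part of what the source reports. "The series", "measured", "known", "first", "only" and "open" are said of these compounds alone.

Series around a shared core: compound 1 `O=C(NS(=O)(=O)c1ccc(F)cc1)c1ccc(Nc2nc(NC3(c4ccc(Cl)cc4)CC3)nc(OCC(F)(F)F)n2)cc1` gives 100% in an ADME assay on microsomes from liver (Homo sapiens) for metabolic stability, with a stated time of 10 min; on this read-out higher numbers stand for a more stable compound and lower numbers for a less stable compound; compound 2 `CCCCCNc1nc(Nc2ccc([N+](=O)[O-])cc2)nc(OCC(F)(F)F)n1` gives 74%; compound 3 `CC(C)C(=O)NCCS(=O)(=O)NC(=O)c1ccc(Nc2nc(NC3(c4ccc(Cl)cc4)CC3)nc(OCC(F)(F)F)n2)cc1` gives 86%. On these three numbers compound 3 stands second highest, with compound 2 its nearest neighbour and compound 1 its furthest. For the measured compounds named here, the only step recorded, a number 14 percentage points lower from compound 1 to compound 3 (beyond the scatter), exchanges the group on the sulfonyl sulfur. Compound 4 `CC(C)(C)CNCCS(=O)(=O)NC(=O)c1ccc(Nc2nc(NC3(c4ccc(Cl)cc4)CC3)nc(OCC(F)(F)F)n2)cc1` keeps the sulfonyl side chain of compound 3 and changes only its end: neopentyl in place of isopropylcarbonyl on an amine nitrogen. Going by the values given here, no measured step touches this amine nitrogen, so the exchange stands without direct precedent; the one step known, a number 14 percentage points lower from compound 1 to compound 3 (beyond the scatter), concerns another position and shows only the size of move this series has produced so far. A step of similar size or none beyond the scatter is therefore expected, a number 10 percentage points lower from compound 3 to compound 4 (within the scatter), with the downward direction slightly favoured because compound 3 at 86% already sits off the top of the set. Compound 4 is expected at 76%, within 55% to 95%.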

Compound 4, percent of the compound remaining: 89%
The estimate for compound 4 lay 13 percentage points below the measured number, within the range that was stated.
By their numbers in this assay, from the lowest: compound 2; then compounds 3 and 4 (each within the scatter of the next); then compound 1.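

In this assay, neopentyl in place of isopropylcarbonyl on the amine nitrogen gives a number 3 percentage points higher from compound 3 to compound 4 (within the scatter), so at this position the read-out does not separate the two groups, although the carbonyl and its hydrogen-bond acceptor are gone. At the sulfonyl sulfur, 2-(neopentylamino)ethyl in place of 4-fluorophenyl gives a number 11 percentage points lower from compound 1 to compound 4 (beyond the scatter), which puts a second chain ending on this nitrogen beyond the scatter from the aryl group of compound 1. No measurement on hand accounts for either step.

On these data alone, whether a carboxylic acid, a cyclohexyl ring or a longer alkyl chain on this amine nitrogen would also stay within the scatter of compound 4 remains open. So does the effect of a shorter or longer link between the nitrogen and the sulfonyl sulfur.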